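A Fluorine Swap on the Sulfonyl Aryl Ring

A few compounds are considered here, and "the series" means these few. Any claim that something is new, unique, unknown or untested is made for them only; others in the source may bear on it.

In an assay on isolated protein for inhibition of malate dehydrogenase, mitochondrial (Sus scrofa), with stated times of 45 min and 30 min (on this read-out higher numbers stand for weaker inhibition and lower numbers for stronger inhibition), compound 1 `O=S(=O)(Nc1ccc2oc(-c3ccccc3)nc2c1)c1ccccc1O` gives only a limit, > 63000 nM. Compound 2 `O=S(=O)(Nc1ccc2oc(-c3ccccc3)nc2c1)c1ccc(O)cc1` likewise reaches only a limit in this assay, > 63000 nM. Compound 3 `C=Cc1ccc(S(=O)(=O)Nc2ccc3oc(-c4ccccc4)nc3c2)cc1` also returns nothing more than a limit, > 63000 nM. The step that the two limits leave unreadable from compound 1 to compound 2 cannot be read, nor can a step that the two limits leave unreadable from compound 1 to compound 3 or a step that the two limits leave unreadable from compound 2 to compound 3, since all three compounds sit at the limit of > 63000 nM in this assay, at which 3 of the 3 values shown sit. Compound 3 therefore stands at the same limit as the other two measured compounds, with no number to set it apart from them.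

Compound 4 `O=S(=O)(Nc1ccc2oc(-c3ccccc3)nc2c1)c1ccccc1F` carries 2-fluorophenyl in place of 4-vinylphenyl on a sulfonyl sulfur. None of the three measured steps has a readable size, so they offer no direction for this change; what they do show is that three different aryl groups on the sulfonyl sulfur all leave the value at the limit. The expected step that the limit leaves unreadable from compound 3 to compound 4 is therefore none beyond the scatter. Compound 4 is estimated at 100000 nM, between 30000 nM and 400000 nM, and is most likely to be reported again only as a limit.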

Compound 4, half-maximal inhibitory concentration: > 63000 nM
Compound 4: only a limit was reported (the forecaster's own chance of this, stated with the estimate: 85%); the middle value is on the limit's open side.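

Going by these compounds alone, compound 4 sits at a limit in this assay, as do compound 1, compound 2 and compound 3, so no step to compound 4 can be read: (the limit of > 63000 nM in this assay, at which 4 of the 4 values shown sit). The compounds shown leave open whether any group on the sulfonyl sulfur would give a measurable half-maximal inhibitory concentration.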